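A few compounds are considered here, and "the series" means these few. Any claim that something is new, unique, unknown or untested is made for them only; others in the source may bear on it.

Three compounds share one core and differ chiefly in the ring carried by the carbonyl. Compound 1 `CCOC(=O)c1[nH]c(=O)c(C#N)cc1C(=O)c1ccc(Cl)cc1` bears a chloro on that ring, compound 2 `CCOC(=O)c1[nH]c(=O)c(C#N)cc1C(=O)c1ccc(C)cc1` a methyl, and compound 3 `O=C(c1ccc([N+](=O)[O-])cc1)c1cc(C(=O)O)c(=O)[nH]c1C(=O)O` a nitro, with acids where the others carry an ester and a nitrile. In an ADME assay on J774.A1 cells (Mus musculus) for cytotoxicity, read by MTT assay, with a stated time of 48 h (on this read-out higher numbers stand for lower toxicity in this test and lower numbers for higher toxicity in this test), compound 2 gives 194000 nM and compound 3 gives 388000 nM. In this assay compound 1 gives only a limit, < 100000 nM, and not a number. Among the two numbers, compound 2 stands lowest, yet its gap to compound 3 is within the scatter, so the two cannot be told apart. Among the measured compounds shown here, the one measured step, an at least 1.9-fold higher number from compound 1 to compound 2 (0.28 log units; that floor lies within the scatter), rests on that limit of < 100000 nM in this assay, at which 1 of the 3 values shown sits, and its true size is therefore unknown. Compound 4 `CCOC(=O)c1[nH]c(=O)c(C#N)cc1C(=O)c1ccc(Br)cc1` differs from compound 2 by bromo in place of methyl on an aromatic carbon. The step from chloro to methyl bears on this: the change now runs back from methyl to a halogen, and read in reverse that step points to a lower number, though its floor lies within the scatter. A modest fall is therefore expected, a 1.8-fold lower number from compound 2 to compound 4 (0.25 log units; within the scatter), and compound 4 is estimated in this assay at 110000 nM, between 40000 nM and 300000 nM, with a real chance that only a limit is reported.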

Compound 4, half-maximal cytotoxic concentration: < 100000 nM
Compound 4: a limit, no number; the forecaster's own chance of this, stated with the estimate: 35%; middle value at least 1.1-fold (0.04 log units) from the limit.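

In this assay compound 4 gives < 100000 nM and that is a limit, not a number. Putting bromo in place of methyl on this aromatic carbon, para to a large group, gives an at least 1.9-fold lower number from compound 2 to compound 4 (0.28 log units; that floor lies within the scatter) and shows that a second halogen, like the chloro of compound 1, ends at a limit where the methyl of compound 2 gave a number. That floor is all that can be said about the size of the change, and the step between the chloro and the bromo cannot be read, because both halogen compounds rest on a limit: the limit of < 100000 nM in this assay, at which 2 of the 4 values shown sit.

The compounds shown leave open how far past the limit the two halogen compounds lie, and so whether a halogen here truly differs from methyl in this test. They also leave open how an amine or a methoxy group would read at this position on the same ester and nitrile core, and compound 3 cannot help, since it differs from the others in more than one place.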